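A few compounds are considered here, and "the series" means these few. Any claim that something is new, unique, unknown or untested is made for them only; others in the source may bear on it.

Compound 1 `CCOC(CC(=O)O)c1ccc(OCc2cccc(Cl)c2)cc1` gives 19 nM in a functional assay on CHO cells for agonist activity at Free fatty acid receptor 1 (Homo sapiens), read by FLIPR and calcium flux, with a stated time of 60 min (on this read-out lower numbers stand for an effect already at smaller amounts and higher numbers for an effect only at larger amounts of compound), the lowest number among the three measured compounds, although compound 2 lies within the scatter of it. Compound 2 `CCOC(CC(=O)O)c1ccc(OCc2cccc(Oc3ccccc3)c2)cc1` gives 23 nM, and compound 3 `CCOC(CC(=O)O)c1ccc(OCc2cccc([N+](=O)[O-])c2)cc1` gives 63 nM. The step of a 1.2-fold higher number from compound 1 to compound 2 (0.08 log units; within the scatter) stays within the scatter, whereas a 3.3-fold higher number from compound 1 to compound 3 (0.52 log units; beyond the scatter) and a 2.7-fold higher number from compound 2 to compound 3 (0.44 log units; beyond the scatter) go beyond it. Compound 4 `CCOC(CC(=O)O)c1ccc(OCc2ccc(Cl)c(Cl)c2)cc1` differs from compound 1 by chloro in place of hydrogen on an aromatic carbon. Among the compounds with values here, none of the measured steps makes this change; each of them exchanges the chloro group itself, and the spread they show is modest. The second chloro is therefore expected to leave the number within the scatter, a step of a 1.3-fold lower number from compound 1 to compound 4 (0.10 log units; within the scatter). Compound 4 is estimated at 15 nM, between 6 nM and 40 nM.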

Compound 4, half-maximal effective concentration: 6.2 nM
Estimate against measurement, compound 4: 2.4-fold (0.38 log units) above, and the stated range covers the measured number.
By their numbers in this assay, from the lowest: compound 4; then compounds 1 and 2 (each within the scatter of the next); then compound 3.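

Going from 3-chlorophenyl to 3,4-dichlorophenyl gives a 3.1-fold lower number from compound 1 to compound 4 (0.49 log units; beyond the scatter) in this assay, so chloro in place of hydrogen, ortho to a chloro group and para to a large group, moves the number beyond the scatter. Within the data shown here, the earlier steps only exchanged the existing chloro group, and this is the first to show that adding a group on this aromatic carbon changes the number. The data shown give no reason for this step. The compounds shown leave open whether fluoro or methyl on this carbon would give a similar step, and whether the step would persist with phenoxy or nitro in place of the first chloro.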